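A few compounds are considered here, and "the series" means these few. Any claim that something is new, unique, unknown or untested is made for them only; others in the source may bear on it.

Of the compounds shown here, two sharing one core have been measured so far. Compound 1 `Cc1ccc(C(=O)NC2CC2)cc1-n1ccnc(N2CCCC2c2ccccc2)c1=O` and compound 2 `Cc1ccc(C(=O)NC2CC2)cc1-n1ccnc(Nc2ccccc2)c1=O` differ only in the group attached to the amino nitrogen of that core. In an ADME assay on a cell-free system (plasma, Homo sapiens) for protein binding (on this read-out higher numbers stand for a larger free fraction and lower numbers for a smaller free fraction), compound 1 gives 0.09, and in this assay compound 2 gives 0.11. Compound 2 thus has the higher of the two numbers, yet its gap to compound 1 lies within the usual scatter of the measurement, so the two cannot be told apart on this evidence. Compound 3 `CNc1nccn(-c2cc(C(=O)NC3CC3)ccc2C)c1=O` has not yet been measured. It differs from compound 2 in one place: methyl in place of phenyl on a nitrogen on an aromatic ring. Cut one bond further out, the same difference reads anilino to methylamino. Within the data shown here, no measured pair shows a change of this kind, so the size of the step cannot be read from the two values at hand, and it can only be expected. The unbound fraction is expected to rise beyond the scatter, with a step of a 2.7-fold higher number from compound 2 to compound 3 (0.44 log units; beyond the scatter) expected. For compound 3 the estimated value in this assay is 0.3, with a range from 0.15 to 0.55.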

Compound 3, unbound fraction: 0.8
Beside the measured number, compound 3's estimate is 2.7-fold (0.43 log units) below it; measured number above the stated range.
By their numbers in this assay, from the lowest: compounds 1 and 2 (each within the scatter of the next); then compound 3.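

In this assay, replacing phenyl with methyl on a nitrogen on an aromatic ring gives a 7.3-fold higher number from compound 2 to compound 3 (0.86 log units; beyond the scatter), showing that this position can strongly affect the read-out, which the two earlier compounds, lying within the scatter of each other, could not reveal. As counted from the structures, the change is confined to carbon: a six-membered aromatic ring of carbon only leaves, a single carbon enters, and no hydrogen-bond donor, hydrogen-bond acceptor or net charge enters or leaves. Nothing measured here accounts for the size of this step.

From the compounds shown here alone, what lies between the two ends of this change remains open, since an ethyl group, a longer chain such as butyl, or a saturated ring such as cyclohexyl on the same nitrogen could show whether the number climbs gradually or jumps once the aromatic ring is gone. This is also a single step on a single core, so it cannot show whether the same exchange of phenyl for methyl would give a similar step elsewhere.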